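Chloro removal on the benzoyl of a hydrazide series

A few compounds are considered here, and "the series" means these few. Any claim that something is new, unique, unknown or untested is made for them only; others in the source may bear on it.

Three hydrazides have been measured in an assay on cells for agonist activity at ecdysone receptor (Bombyx mori), read by a luciferase reporter, with a stated time of 24 h; on this read-out lower numbers stand for an effect already at smaller amounts and higher numbers for an effect only at larger amounts of compound. Compound 1 `CC(C)(C)N(NC(=O)c1ccccc1Cl)C(=O)c1ccccc1Cl` gives 331 nM. Compound 2 `CCc1ccc(C(=O)NN(C(=O)c2ccccc2Cl)C(C)(C)C)cc1` gives 5.75 nM. Compound 3 `CC(C)(C)N(NC(=O)c1cccc(Cl)c1Cl)C(=O)c1ccccc1Cl` gives 9.33 nM. Compound 2 and compound 3 share a core and differ in one place, (4-ethylphenyl in place of 2,3-dichlorophenyl on a carbonyl carbon); their numbers sit within the scatter of each other, a 1.6-fold higher number from compound 2 to compound 3 (0.21 log units; within the scatter). Against compound 1, both stand far apart: a 58-fold lower number from compound 1 to compound 2 (1.76 log units; beyond the scatter), and a 35-fold higher number from compound 3 to compound 1 (1.55 log units; beyond the scatter).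

Compound 4 `CCc1ccc(C(=O)NN(C(=O)c2ccccc2)C(C)(C)C)cc1` is not yet measured. It differs from compound 2 by hydrogen in place of chloro on an aromatic carbon. The same kind of change is seen between compound 3 and compound 1, (hydrogen in place of chloro on an aromatic carbon), where it made a large step, a 35-fold higher number from compound 3 to compound 1 (1.55 log units; beyond the scatter). The two places are not the same: in the measured pair the carbon is ortho to a chloro group and meta to a large group, whereas in compound 2 the carbon is ortho to a large group, and the change is on the other benzoyl of the core. Going by the values given here, that measured step is the only guide available, so it is taken as a sign of direction but not of size.

Among the compounds with values here, from compound 2 to compound 4 a loss is expected, a 4.3-fold higher number from compound 2 to compound 4 (0.64 log units; beyond the scatter), smaller than the one seen between compound 3 and compound 1. The place differs in the way set out above. Compound 4 is therefore estimated at 25 nM in this assay, with a range from 6 nM to 120 nM.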

Compound 4, half-maximal effective concentration: 4.9 nM
For compound 4 the middle estimate is 5.1-fold (0.71 log units) above the measured one, and the stated range ends above it.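

With the chloro gone from the 2-chlorophenyl group, the number in this assay stays within the scatter: a 1.2-fold lower number from compound 2 to compound 4 (0.07 log units; within the scatter). The same written change, hydrogen in place of chloro on an aromatic carbon, therefore does not carry from one core to the other, and the two steps stand clearly apart: the same change on two cores in this assay, a 35-fold higher number (1.55 log units; beyond the scatter) from compound 3 to compound 1 and a 1.2-fold lower number (0.07 log units; within the scatter) from compound 2 to compound 4, 42-fold (1.62 log units) apart, beyond the scatter of two such steps This shows that the large step seen on the core of compound 1 is no general price of losing a chloro in this series, but it does not show what sets the two steps apart, as the two pairs differ both in where the chloro sits and in the rest of the molecule, and two pairs give no rule for the other compounds.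

The compounds shown leave open whether the 2-chlorophenyl position of compound 2 tolerates other groups as well, such as a fluoro, a methyl or a methoxy in place of the chloro. Also open, going by these compounds, is whether the result depends on the ethyl of the 4-ethylphenyl group, which a longer chain such as butyl, or a hydrogen in place of the ethyl, would test on the same core.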